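The compounds below may be only part of what the source reports. "The series", "measured", "known", "first", "only" and "open" are said of these compounds alone.

Values from a functional assay on HCT-116 cells (Homo sapiens) for inhibition, read by WST assay, with stated times of 72 h and 2 h (on this read-out lower numbers stand for stronger inhibition and higher numbers for weaker inhibition), are as follows.
compound 1 `C#CCOC(c1cccs1)c1cc2ccccc2nc1Cl` > 100000 nM
compound 2 `Fc1ccc(COC(c2cccs2)c2cc3ccccc3nc2Cl)cc1` "not active" (no number reported)

The entry for compound 1 is a limit of the assay and not a number. Among the compounds with values here, compound 2 has no single number: it is reported as "not active" (no number reported) and the only figure near it is the limit of > 100000 nM in this assay, at which 1 of the 2 values shown sits, so far.

Compound 3 `Clc1ccc(COC(c2cccs2)c2cc3ccccc3nc2Cl)cc1` differs from compound 2 in one place, with chloro in place of fluoro on an aromatic carbon, para to a large group (chloro in place of fluoro on an aromatic carbon). The same difference reads 4-fluorobenzyl to 4-chlorobenzyl. Within the data shown here, no measured step gives a size for this change. In this assay no step beyond the scatter is expected, in either direction. This expectation rests on compound 2 being reported as "not active" (no number reported) in that read-out. A report without a number is also likely for compound 3. The estimated value for compound 3 is 80000 nM within an expected range of 20000 nM to 150000 nM if a number is reported at all.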

Compound 3, half-maximal inhibitory concentration: "not active" (no number reported)
No number was reported for compound 3, and the estimate cannot be compared.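

Within the data shown here, compound 2 and compound 3 are both reported without a number in this assay, so no step between them can be read. The compounds shown leave open whether 4-fluorobenzyl and 4-chlorobenzyl differ in inhibition, and which change to the shared core would give a measurable value.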